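This account rests on a few compounds, and the source may have more. Where it says the series, first, only, none or still open, it means among the compounds named here.

Compound 1, `COC(=O)c1ccc(NCc2cncn2Cc2cccc(C)c2)cc1-c1ccccc1`, in a toxicity assay on NIH3T3 cells (Mus musculus) for cytotoxicity, read by resazurin assay (a lower number here means that less compound is needed, a higher number that more compound is needed for the effect), gives only a limit, > 10000 nM.
Compound 2, `COC(=O)c1ccc(NCc2cncn2Cc2ccccc2N)cc1-c1ccccc1`, in this assay gives 25000 nM.
Compound 3, `COC(=O)c1ccc(NCc2cncn2Cc2cccc(Cl)c2)cc1-c1ccccc1`, in this assay gives only a limit, > 10000 nM.

Compound 3 thus stands at a limit of this assay rather than at a number, and one further value of the three is a limit as well (the limit of > 10000 nM in this assay, at which 2 of the 3 values shown sit); where it sits against its two neighbours cannot be read. Within the data shown here, the steps a step that the limit leaves unreadable from compound 1 to compound 2, a step that the two limits leave unreadable from compound 1 to compound 3 and a step that the limit leaves unreadable from compound 2 to compound 3 are all of unreadable size, so no measured step gives a usable scale.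

Compound 4, `COC(=O)c1ccc(NCc2cncn2Cc2ccc(Cl)cc2)cc1-c1ccccc1`, has not yet been measured. It differs from compound 3 in a single place: 4-chlorophenyl in place of 3-chlorophenyl on a saturated chain carbon bound to an aromatic nitrogen. Among the measured compounds shown here, none of the measured steps moves the chloro from one place on that ring to another, so none bears directly on this change. Because two of the three values shown sit at the limit (the limit of > 10000 nM in this assay, at which 2 of the 3 values shown sit), a limit is also the most likely outcome for compound 4. Compound 4 is therefore expected to give about 15000 nM in this assay, between 7000 nM and 40000 nM, and the expected step that the limit leaves unreadable from compound 3 to compound 4 is one of no clear direction beyond the scatter.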

Compound 4, half-maximal effective concentration: 25000 nM
Estimate against measurement, compound 4: 1.7-fold (0.22 log units) below, within the range that was stated.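

With compound 4, a chlorophenyl group on this saturated chain carbon bound to an aromatic nitrogen has a number rather than a limit in this assay. Putting 4-chlorophenyl in place of 2-aminophenyl at this place gives no change at the digits printed from compound 2 to compound 4 (within the scatter), so the two groups cannot be told apart in this read-out, although they share neither the substituent nor its place on the ring. The steps to compound 4 from compound 3 and from compound 1 cannot be read, because compound 3 and compound 1 each stand at a limit: the limit of > 10000 nM in this assay, at which 2 of the 4 values shown sit.

On these data alone, whether moving the chloro from 3-chlorophenyl to 4-chlorophenyl changes the reading at all therefore stays open, and so does whether the 3-methylphenyl group differs from 4-chlorophenyl in this assay. Also open, as far as these compounds go, is how a carboxylic acid or a dimethylamino group in place of the chloro would read in this assay, and whether any group at this place would give a value clearly apart from those of compound 2 and compound 4.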